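Acyl branching at the ester of the shared core

This account rests on a few compounds, and the source may have more. Where it says the series, first, only, none or still open, it means among the compounds named here.

Compound 1 `CC(C)C(=O)O[C@H]1C[C@@H](C)C=C2C=C[C@H](C)[C@H](CC[C@@H]3C[C@@H](O)CC(=O)O3)C21` carries an isopropylcarbonyl ester on the shared core. In an assay for inhibition of 3-hydroxy-3-methylglutaryl-coenzyme A reductase (Rattus norvegicus) (a higher number here means a weaker inhibitor, a lower number a stronger inhibitor), compound 1 gives 7.7 nM, the second highest of the three numbers in hand. Compound 2 `CCC(CC)(CC)C(=O)O[C@H]1C[C@@H](C)C=C2C=C[C@H](C)[C@H](CC[C@@H]3C[C@@H](O)CC(=O)O3)C21` bears a 1,1-diethylpropyl group on the carbonyl carbon, and in this assay compound 2 gives 1.4 nM, a step of a 5.5-fold lower number from compound 1 to compound 2 (0.74 log units; beyond the scatter). Compound 3 `CC(=O)O[C@H]1C[C@@H](C)C=C2C=C[C@H](C)[C@H](CC[C@@H]3C[C@@H](O)CC(=O)O3)C21` has a methyl on the carbonyl carbon; in this assay compound 3 gives 269 nM, with a 35-fold higher number from compound 1 to compound 3 (1.54 log units; beyond the scatter) and a 190-fold higher number from compound 2 to compound 3 (2.28 log units; beyond the scatter). Across these three, more branching on the carbonyl carbon goes with a lower number, and none of them goes against that.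

Compound 4 `C[C@H]1C=C2C=C[C@H](C)[C@H](CC[C@@H]3C[C@@H](O)CC(=O)O3)C2[C@@H](OC(=O)C(C)(C)C)C1` differs from compound 1 by methyl in place of hydrogen on a saturated chain carbon bound to a carbonyl carbon and two saturated chain carbons, read one bond further out as isopropyl to tert-butyl. The step to compound 2 bears most directly on this change, as tert-butyl lies between isopropyl and 1,1-diethylpropyl in branching. For compound 4 the expected step is a 1.9-fold lower number from compound 1 to compound 4 (0.28 log units; within the scatter), a lowering smaller than a 5.5-fold lower number from compound 1 to compound 2 (0.74 log units; beyond the scatter). Compound 4 is expected to come in at 4 nM, estimated between 1.5 nM and 12 nM.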

Compound 4, half-maximal inhibitory concentration: 2.7 nM
The estimate for compound 4 lay 1.5-fold (0.17 log units) above the measured number, and the stated range covers the measured number.
By their numbers in this assay, from the lowest: compounds 2 and 4 (each within the scatter of the next); then compound 1; then compound 3.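

One added methyl on the saturated chain carbon bound to the carbonyl carbon is enough to register at this ester, turning isopropyl into tert-butyl with a 2.9-fold lower number from compound 1 to compound 4 (0.46 log units; beyond the scatter) and showing that the trend holds at a single-atom change. The larger groups do not separate in the same way: tert-butyl and 1,1-diethylpropyl cannot be told apart (a 1.9-fold higher number from compound 2 to compound 4 (0.29 log units; within the scatter)), so the further ethyl branches show no measurable gain over tert-butyl, while the distance back to methyl remains wide (a 100-fold lower number from compound 3 to compound 4 (2.00 log units; beyond the scatter)). No measurement in hand accounts for these steps.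

On these data alone, whether branching itself or simply the size of the acyl group tracks with the number stays open, and a straight butyl chain would bear on this. As far as these compounds go, a phenyl ring or a hydroxyl on the acyl group also remains untested.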